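The compounds below may be only part of what the source reports. "The series", "measured", "known", "first", "only" and "open" are said of these compounds alone.

Compound 1 `CC#CCC(C)[C@H](O)/C=C/[C@H]1[C@H](O)C[C@]2(CCCCCO)C/C(=C/CCCC(=O)O)C[C@H]12` sits at the weak end of the series: in a functional assay for inhibition, with Homo sapiens as the target (on this read-out lower numbers stand for stronger inhibition and higher numbers for weaker inhibition), compound 1 gives 11000 nM, the highest number of the three measured. Compound 2 `CC#CCC(C)[C@H](O)/C=C/[C@H]1[C@H](O)C[C@]2(C#CCCCI)C/C(=C/CCCC(=O)O)C[C@H]12` gives 200 nM in this assay, and compound 3 `CC#CCC(C)[C@H](O)/C=C/[C@H]1[C@H](O)C[C@]2(C#CCCCO)C/C(=C\CCCC(=O)O)C[C@H]12` gives 10 nM.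

Compound 4 `CC#CCC(C)[C@H](O)/C=C/[C@H]1[C@H](O)C[C@]2(C#CCCCO)C/C(=C/CCCC(=O)O)C[C@H]12` is not yet measured. Its change from compound 1 is 5-hydroxypent-1-yn-1-yl in place of 5-hydroxypentyl on a saturated ring carbon. Within the data shown here, one measured step bears on it: a 55-fold lower number from compound 1 to compound 2 (1.74 log units; beyond the scatter), in which the saturated chain also became a chain with a triple bond, though ending in iodine rather than hydroxy. Among the measured compounds shown here, compound 3 carries the same 5-hydroxypent-1-yn-1-yl group as compound 4 but differs from it elsewhere, so no step between them is counted; its number shows only that this group is compatible with strong inhibition.

A large step downward in this assay is therefore expected from compound 1 to compound 4, a 110-fold lower number from compound 1 to compound 4 (2.04 log units; beyond the scatter), and compound 4 is estimated at 100 nM, with a range from 20 nM to 600 nM.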

Compound 4, half-maximal inhibitory concentration: 200 nM
Estimate against measurement, compound 4: 2.0-fold (0.30 log units) below; the measured number falls inside the stated range.
By their numbers in this assay, from the lowest: compound 3; then compounds 2 and 4 (each within the scatter of the next); then compound 1.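

In this assay the triple bond is now seen on its own, with the terminal hydroxy kept: 5-hydroxypent-1-yn-1-yl in place of 5-hydroxypentyl gives a 55-fold lower number from compound 1 to compound 4 (1.74 log units; beyond the scatter) with no second change mixed in. The end of the alkynyl chain does not separate the pair carrying hydroxy and iodo, as no change at the digits printed from compound 2 to compound 4 (within the scatter) is printed for hydroxy in place of iodo. Double-bond geometry does separate a pair, with a 20-fold higher number from compound 3 to compound 4 (1.30 log units; beyond the scatter) for a double bond drawn Z in compound 3 and E in compound 4, and that reading carries one caution: the fact that one of compounds 3 and 4 is drawn with a defined configuration and the other without, at the place where they differ.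

Going by these compounds, whether the chain end stays this tolerant with an amine, a carboxylic acid or a longer chain remains open. Also open, on these data alone, is whether the Z double bond gives a similar step with the iodo end or the saturated 5-hydroxypentyl chain.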